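A few compounds are considered here, and "the series" means these few. Any claim that something is new, unique, unknown or untested is made for them only; others in the source may bear on it.

Of the compounds shown here, two built on a shared core have so far been tested in a functional assay on NCI-H322M cells (Homo sapiens) for inhibition, read by sulforhodamine B assay, with a stated time of 48 h; a higher number here means that more compound is tolerated, a lower number that less compound is tolerated. Compound 1 `COc1ccc(CNc2nc3cc(N)cc(N)c3nc2-c2ccccc2)cc1OC` gives 100000 nM. Compound 2 `Nc1cc(N)c2nc(-c3ccccc3)c(NCc3ccc(F)cc3)nc2c1` gives 40700 nM, the lowest of the two numbers. Among the compounds with values here, the single measured step, a 2.5-fold lower number from compound 1 to compound 2 (0.39 log units; beyond the scatter), joins them. Compound 3 `COc1ccc(CNc2nc3cc(N)cc(N)c3nc2-c2ccccc2)cc1` differs from compound 2 by methoxy in place of fluoro on an aromatic carbon, which partly reverses that earlier change. Because a 2.5-fold lower number from compound 1 to compound 2 (0.39 log units; beyond the scatter) went downward when both methoxy groups left, bringing one back is expected to move the number upward, though by less. Compound 3 is therefore estimated at 65000 nM, spanning 30000 nM to 140000 nM. That amounts to an expected step of a 1.6-fold higher number from compound 2 to compound 3 (0.20 log units; within the scatter).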

Compound 3, concentration lethal to 50% of the cells: < 100000 nM
Compound 3 gave a limit, no number; the forecaster's own chance of this, stated with the estimate: 15%; the middle value lies beyond the limit too.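

In this assay compound 3 gives < 100000 nM, which is a limit and not a number. The result shows a number no higher from compound 1 to compound 3 (the limit leaves the size open). The step joining compound 3 to compound 2 cannot be read, so methoxy in place of fluoro on the aromatic carbon para to a large group gains no measured size. The result adds only one reading that carries no exact value: the limit of < 100000 nM in this assay, at which 1 of the 3 values shown sits.

Going by these compounds, whether 4-methoxybenzyl and 4-fluorobenzyl truly differ here stays open. So does what an amine or a carboxylic acid would do at this same position.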